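The source may hold more compounds than are shown below. What is called first, only, known or untested is meant among the compounds shown, and "the series" means these compounds.

Compound 1 `O=C(NCCCCc1ccccc1)n1c(=O)oc2ccccc21`, in an assay on HEK293 cells for inhibition of acid ceramidase (Homo sapiens), with a stated time of 10 min (a higher number here means a weaker inhibitor, a lower number a stronger inhibitor), gives 64 nM. Compound 2 `O=C(NCCCc1ccccc1)n1c(=O)oc2ccccc21` gives 55 nM. Compound 3 `O=C(c1ccccc1)c1ccc2c(c1)oc(=O)n2C(=O)NCCCCc1ccccc1` gives 29 nM.

Compound 1 stands at the highest number of the three, though its nearest neighbour is separated from it only by a 1.2-fold lower number from compound 1 to compound 2 (0.07 log units; within the scatter), a step within the scatter, while a 2.2-fold lower number from compound 1 to compound 3 (0.34 log units; beyond the scatter) goes beyond it. Compound 4 `O=C(NCCCCc1ccccc1)n1c(=O)oc2ccc(Cl)cc21` differs from compound 1 by chloro in place of hydrogen on an aromatic carbon. For the measured compounds named here, only one measured step alters that same ring of the shared core, the modest one given as a 2.2-fold lower number from compound 1 to compound 3 (0.34 log units; beyond the scatter); the chain change in a 1.2-fold lower number from compound 1 to compound 2 (0.07 log units; within the scatter) does not bear on it. A small lowering or no step beyond the scatter is therefore expected, about a 1.4-fold lower number from compound 1 to compound 4 (0.15 log units; within the scatter). Compound 4 is estimated at 45 nM, with a range from 20 nM to 120 nM.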

Compound 4, half-maximal inhibitory concentration: 15 nM
The estimate for compound 4 lay 3.0-fold (0.48 log units) above the measured number; the whole stated range lies above it.
By their numbers in this assay, from the lowest: compounds 4, 3, 2 and 1 (each within the scatter of the next, the first and the last beyond it).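

The step of a 4.3-fold lower number from compound 1 to compound 4 (0.63 log units; beyond the scatter) shows that a single chlorine atom on this aromatic carbon, meta to a fused ring and para to a fused ring, is enough to move the number beyond the scatter. For the compounds shown here, until now, the only ring change on record was the larger benzoyl group. Nothing available accounts for this step.

On these data alone, whether fluoro, methyl or methoxy on this carbon would give a similar step remains open, as does whether chloro would act the same way on the shorter chain of compound 2.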